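Restoring the amino hydrogen beside a methoxybenzyl group

The compounds below may be only part of what the source reports. "The series", "measured", "known", "first", "only" and "open" are said of these compounds alone.

Measured compounds in a functional assay on BE(2)-C cells (Homo sapiens) for inhibition, read by MTT assay, with a stated time of 72 h; a higher number here means a weaker inhibitor of growth, a lower number a stronger inhibitor of growth:
compound 1, `O=S(=O)(NCCCCNCc1ccc(Br)cc1)c1cc(C(F)(F)F)cc(C(F)(F)F)c1`, 2200 nM
compound 2, `O=S(=O)(NCCCNCC1COc2ccccc2O1)c1cc(C(F)(F)F)cc(C(F)(F)F)c1`, 2800 nM
compound 3, `CN(CCCNS(=O)(=O)c1cc(C(F)(F)F)cc(C(F)(F)F)c1)Cc1ccccc1`, 28000 nM

Compound 3 stands highest of the three, that is, as the weakest inhibitor of growth among them. Compound 2 gives 2800 nM, well below compound 3, and compound 1 lies further still. For the measured compounds named here, the one step that bears on the next move is a 13-fold higher number from compound 1 to compound 3 (1.10 log units; beyond the scatter), the only change that placed a methyl on the amino nitrogen in place of its hydrogen.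

Compound 4, `COc1cccc(CNCCCNS(=O)(=O)c2cc(C(F)(F)F)cc(C(F)(F)F)c2)c1`, takes the opposite route: (3-methoxybenzyl)amino in place of benzyl(methyl)amino on a saturated chain carbon, three bonds along the chain from a sulfonamide nitrogen. It thus returns to an amino nitrogen bearing a hydrogen, as in compound 1 and compound 2, both of which gave lower numbers than compound 3 in this assay. Going by the values given here, the aromatic substituent changes too, from none to methoxy, and no measured pair shows what that alone does. A step of about the size seen from compound 1 to compound 3, but downward, is therefore expected, written as a 9.3-fold lower number from compound 3 to compound 4 (0.97 log units; beyond the scatter). Compound 4 is estimated to give about 3000 nM, between 1200 nM and 9000 nM.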

Compound 4, concentration for 50% growth inhibition: 4500 nM
For compound 4 the middle estimate is 1.5-fold (0.18 log units) below the measured one, and the stated range covers the measured number.
By their numbers in this assay, from the lowest: compounds 1, 2 and 4 (each within the scatter of the next, the first and the last beyond it); then compound 3.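

In this assay, for the compounds shown here, the step of a 6.2-fold lower number from compound 3 to compound 4 (0.79 log units; beyond the scatter) shows that the higher number of compound 3 is not tied to the benzyl group as such, since (3-methoxybenzyl)amino, with its hydrogen on the amino nitrogen, falls among the lower numbers; compound 3 is now the only one of the four with a methyl there, and no compound goes against this. The step of a 1.6-fold higher number from compound 2 to compound 4 (0.21 log units; within the scatter) is within the scatter, so 3-methoxyphenyl and 2,3-dihydro-1,4-benzodioxin-2-yl cannot be told apart at this place, whereas a 2.0-fold higher number from compound 1 to compound 4 (0.31 log units; beyond the scatter) is a modest step just beyond it. Nothing available explains these differences.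

As far as these compounds go, the change from compound 3 to compound 4 removes the methyl and adds the methoxy together, so their separate shares remain open. A plain benzylamino group on the same chain would separate them, and an ethyl on the amino nitrogen would extend the comparison.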